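The source may report more compounds than this note shows. Statements on the series, on what has been measured and on what is new or still open speak of the compounds shown alone.

Compound 1 `ClCc1cccc(Cn2cnc3ncnc(Cl)c32)c1`: 7070 nM
Compound 2 `ClCc1cccc(Cn2cnc3c(Cl)ncnc32)c1`: 2340 nM

In a functional assay on SN12C cells (Homo sapiens) for cytotoxicity, read by sulforhodamine B assay, with a stated time of 48 h (on this read-out lower numbers stand for stronger inhibition of growth and higher numbers for weaker inhibition of growth), compound 1 gives 7070 nM, the highest of the two numbers; its nearest neighbour, compound 2, gives a lower number, and that gap lies beyond the usual scatter. Compound 3 `ClCc1cccc(Cn2cnc3nc(Cl)nc(Cl)c32)c1` has not yet been measured. It differs from compound 1 by chloro in place of hydrogen on an aromatic carbon. Among the compounds with values here, no measured pair shows this change, so the step cannot be read from the data. A step toward a lower number that does not clearly leave the scatter is expected, a 1.6-fold lower number from compound 1 to compound 3 (0.20 log units; within the scatter). For compound 3 the estimate is 4500 nM, with a range from 1500 nM to 14000 nM.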

Compound 3, concentration for 50% growth inhibition: 1440 nM
Compound 3: the middle estimate sits 3.1-fold (0.49 log units) above what was measured; the measured number lies below the stated range.
By their numbers in this assay, from the lowest: compounds 3 and 2 (each within the scatter of the next); then compound 1.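

In this assay, chloro in place of hydrogen on the aromatic carbon between two ring nitrogen atoms gives a 4.9-fold lower number from compound 1 to compound 3 (0.69 log units; beyond the scatter), a modest gain in growth inhibition. Within the data shown here, this is the first view of this position, and it shows that the position accepts a chloro group without losing activity in these cells. No measurement here explains why the number falls.

As far as these compounds go, with a single change at this position, it remains open whether the gain is specific to chloro. An amine or a methoxy group in the same place could give a quite different number.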